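This account rests on a few compounds, and the source may have more. Where it says the series, first, only, none or still open, it means among the compounds named here.

Working notes on the series, read in a physicochemical assay for solubility, read by nephelometry, in phosphate buffer, measured as kinetic solubility, at pH 6.5; a higher number here means a more soluble compound, a lower number a less soluble compound. Compound 1 `CCOC(=O)C1=C(C)N/C(=C/c2cc(C)n(-c3cccc(C(F)(F)F)c3)c2C)C1=O` gives 2.1 ug/mL. Compound 2 `CCOC(=O)C1=C(C)N/C(=C/c2cc(C)n(-c3ccc(Br)cc3)c2C)C1=O` gives 2.1 ug/mL, level with compound 1 at the digits shown. Compound 3 `CCOC(=O)C1=C(C)N/C(=C/c2cc(C)n(-c3cccc(OC)c3)c2C)C1=O` gives < 1.6 ug/mL, which is a limit of the assay and not a number.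

The next structure is compound 4 `CCOC(=O)C1=C(C)N/C(=C/c2cc(C)n(-c3ccc(SC)cc3)c2C)C1=O`, which differs from compound 1 as follows: 4-(methylsulfanyl)phenyl in place of 3-(trifluoromethyl)phenyl on an aromatic nitrogen. The change is 4-(methylsulfanyl)phenyl in place of 3-(trifluoromethyl)phenyl on an aromatic nitrogen, with the core of compound 1 left as it is.

Among the compounds with values here, the closest precedent is no change at the digits printed from compound 1 to compound 2 (within the scatter), which swaps the same group at the same place for 4-bromophenyl and stays within the scatter. The other two steps, an at least 1.3-fold lower number from compound 1 to compound 3 (0.11 log units; that floor lies within the scatter) and an at least 1.3-fold lower number from compound 2 to compound 3 (0.11 log units; that floor lies within the scatter), reach only a floor that also lies within the scatter. No measured change of this aryl group therefore goes beyond the scatter, and none is expected here in this assay.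

The expected step is a 1.1-fold lower number from compound 1 to compound 4 (0.02 log units; within the scatter), no larger than the scatter. For compound 4 the estimated value is 2 ug/mL, with an expected range of 1.2 ug/mL to 3.6 ug/mL. A reading reported only as a limit would not be a surprise.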

Compound 4, solubility: 1.6 ug/mL
Estimate against measurement, compound 4: 1.3-fold (0.10 log units) above, and the stated range covers the measured number.
By their numbers in this assay, from the lowest: compounds 4, 1 and 2 (each within the scatter of the next).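

In this assay, placing 4-(methylsulfanyl)phenyl on the aromatic nitrogen of the five-membered aromatic ring gives two readable steps, a 1.3-fold lower number from compound 1 to compound 4 (0.12 log units; within the scatter) and a 1.3-fold lower number from compound 2 to compound 4 (0.12 log units; within the scatter). This brings a sulfur-bearing aryl group to this position and gives step sizes that can be read, where the steps to compound 3 reach only a floor, yet no readable exchange of the aryl group here goes beyond the scatter. Compound 3 stands as a limit of the assay and not a number, < 1.6 ug/mL. The remaining step is a number no lower from compound 3 to compound 4 (the limit leaves the size open), and its size cannot be read: the limit of < 1.6 ug/mL in this assay, at which 1 of the 4 values shown sits.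

As far as these compounds go, whether an amine or a carboxylic acid on this aryl group would move the number in this assay beyond the scatter remains open. The compounds shown also give no number clear of the scatter, so it stays open how far any change at this position can shift the reading.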